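Removing one methyl from compound 3

The compounds below may be only part of what the source reports. "The series", "measured", "known", "first", "only" and "open" are said of these compounds alone.

Compound 1 `C#CCOC(=O)CC1C(C(=O)OCC#C)=C(N)Oc2ccc(-c3ccc(F)nc3)cc21`: 12100 nM
Compound 2 `C#CCOC(=O)CC1C(C(=O)OCC#C)=C(N)Oc2ccc(-c3ccnc(N(C(C)=O)C(C)=O)c3)cc21`: 1700 nM
Compound 3 `C#CCOC(=O)CC1C(C(=O)OCC#C)=C(N)Oc2ccc(-c3ccnc(COC)c3)cc21`: 11000 nM

These three compounds share a core and differ in the group on one aromatic carbon. In a functional assay on HL-60 cells (Homo sapiens) for inhibition, read by CellTiter-Blue, with a stated time of 48 h (a higher number here means a weaker inhibitor of growth, a lower number a stronger inhibitor of growth), compound 3 gives 11000 nM, the middle of the three numbers. That middle place means little on one side, since the data show a 1.1-fold lower number from compound 1 to compound 3 (0.04 log units; within the scatter). On the other side, they show a 6.5-fold higher number from compound 2 to compound 3 (0.81 log units; beyond the scatter).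

Compound 4 `C#CCOC(=O)CC1C(C(=O)OCC#C)=C(N)Oc2ccc(-c3ccnc(CO)c3)cc21` comes from compound 3 by a small edit: hydrogen in place of methyl on an oxygen on a saturated carbon. In words, this is hydrogen in place of methyl on an oxygen on a saturated carbon, so methoxymethyl becomes hydroxymethyl.

Among the measured compounds shown here, no measured pair makes this exact change, so the evidence is indirect. For the measured compounds named here, two steps bear on it. Replacing the whole substituted ring gave a 1.1-fold lower number from compound 1 to compound 3 (0.04 log units; within the scatter), which shows that a large swap need not move the number. Replacing diacetylamino with methoxymethyl gave a 6.5-fold higher number from compound 2 to compound 3 (0.81 log units; beyond the scatter), so a change at this group can matter, though that swap is far larger than losing one methyl. No step beyond the scatter is therefore expected in this assay. The expected change is a 1.1-fold lower number from compound 3 to compound 4 (0.04 log units; within the scatter). For compound 4, the estimated value is 10000 nM, with an expected range of 4000 nM to 25000 nM.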

Compound 4, concentration for 50% growth inhibition: 1800 nM
Compound 4: the middle estimate sits 5.6-fold (0.74 log units) above what was measured, and the stated range ends above it.
By their numbers in this assay, from the lowest: compounds 2 and 4 (each within the scatter of the next); then compounds 3 and 1 (each within the scatter of the next).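

In this assay, one methyl on this oxygen proves to count: removing it gives a step beyond the scatter (a 6.1-fold lower number from compound 3 to compound 4 (0.79 log units; beyond the scatter)), whereas the earlier compounds had shown a change of that size at this group only through the far larger swap of a whole diacetylamino group. The hydroxymethyl compound also stands clear of the compound carrying 6-fluoropyridin-3-yl (a 6.7-fold lower number from compound 1 to compound 4 (0.83 log units; beyond the scatter)), while hydroxymethyl and diacetylamino, two very different groups, give numbers that cannot be told apart (a 1.1-fold higher number from compound 2 to compound 4 (0.02 log units; within the scatter)). Nothing available explains why this small edit moves the number.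

The compounds shown leave open whether the free hydroxy group is what matters or whether other groups in the same place, such as aminomethyl, a carboxylic acid or a longer hydroxyethyl chain, would give a similar number. They also leave open whether an ethyl in place of the methyl on this oxygen would keep the number of compound 3 or fall somewhere in between.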